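Lengthening the ester chain of compound 3

The compounds below may be only part of what the source reports. "The series", "measured", "known", "first", "only" and "open" are said of these compounds alone.

Measured in a functional assay on PA-1 cells (Homo sapiens) for cytotoxicity, read by colony formation; on this read-out higher numbers stand for weaker inhibition and lower numbers for stronger inhibition:
compound 1 `COC(=O)C1=CO[C@@H](O[C@@H]2O[C@H](COC(c3ccccc3)(c3ccccc3)c3ccccc3)[C@@H](O)[C@H](O)[C@H]2O)[C@@H]2[C@@H](C)[C@@H](O)C[C@H]12`: 2.42 ug/mL
compound 2 `COC(=O)C1=CO[C@@H](O[C@@H]2O[C@H](COC(c3ccccc3)(c3ccccc3)c3ccccc3)[C@@H](OC(=O)O)[C@H](OC(C)=O)[C@H]2OC(C)=O)[C@@H]2[C@@H](C)[C@@H](OC(C)=O)C[C@H]12`: 1.2 ug/mL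
compound 3 `CCC(=O)OC[C@H]1O[C@@H](O[C@@H]2OC=C(C(=O)OC)[C@H]3C[C@H](OC(C)=O)[C@H](C)[C@@H]23)[C@H](OC(C)=O)[C@@H](OC(C)=O)[C@@H]1OC(C)=O`: 2.85 ug/mL

Compound 3 (2.85 ug/mL) lies within the usual scatter of compound 1 (2.42 ug/mL). Compound 2 gives 1.2 ug/mL. The gap between compound 3 and compound 2 lies beyond the scatter, so compound 3 inhibits more weakly than compound 2. Compound 4 `CCCCCCCCCCCC(=O)OC[C@H]1O[C@@H](O[C@@H]2OC=C(C(=O)OC)[C@H]3C[C@H](OC(C)=O)[C@H](C)[C@@H]23)[C@H](OC(C)=O)[C@@H](OC(C)=O)[C@@H]1OC(C)=O` has not yet been measured. It carries nonyl in place of hydrogen on a saturated chain carbon, two bonds along the chain from a carbonyl carbon. Going by the values given here, no measured pair isolates such a change, so in this assay no shift beyond the scatter is expected, and the direction remains open. The expected change is small (a 1.1-fold lower number from compound 3 to compound 4 (0.06 log units; within the scatter)). For compound 4 the estimated value is 2.5 ug/mL (range 1 ug/mL to 6.5 ug/mL).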

Compound 4, half-maximal inhibitory concentration: 0.42 ug/mL
Estimate against measurement, compound 4: 6.0-fold (0.77 log units) above, outside the stated range (below it).
By their numbers in this assay, from the lowest: compound 4; then compounds 2, 1 and 3 (each within the scatter of the next, the first and the last beyond it).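

In this assay, nonyl in place of hydrogen on a saturated chain carbon, two bonds along the chain from a carbonyl carbon, gives a 6.8-fold lower number from compound 3 to compound 4 (0.83 log units; beyond the scatter). Going by these compounds alone, this is the first single-place change, and it shows that the number at this position of the ester chain responds to the added nonyl. Nothing given here explains the shift.

The compounds shown leave open whether the number falls steadily with chain length or peaks at some intermediate chain, such as butyl. They also leave open whether a longer chain, or an amine or carboxylic acid at the chain end, would keep the lower number.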